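This account rests on a few compounds, and the source may have more. Where it says the series, first, only, none or still open, it means among the compounds named here.

compound 1 `Cc1ccc(SCc2ccc(C(=O)Nc3ccccc3N)cc2)cc1` gives 84%
compound 2 `Nc1ccccc1NC(=O)c1ccc(CSc2nccc(C(F)(F)F)n2)cc1` gives 93.1%
compound 3 `CC(C)(C)c1ccc(SCc2ccc(/C=C/C(=O)Nc3ccccc3N)cc2)cc1` gives 39%

In a functional assay on HCT-116 cells (Homo sapiens) for inhibition, read by CCK-8 assay, with a stated time of 72 h, tested at 8 uM (on this read-out lower numbers stand for less inhibition of growth and higher numbers for more inhibition of growth at the one concentration tested), compound 1 at 84% cannot be told apart from compound 2 and stands far above compound 3 on these numbers. Compound 4 `Nc1ccccc1NC(=O)c1ccc(CSc2ccc(Cl)cc2)cc1` alters compound 1 in one place chloro in place of methyl on an aromatic carbon with chloro in place of methyl on an aromatic carbon, so that 4-methylphenyl becomes 4-chlorophenyl. Going by the values given here, no measured pair shows this swap, so nothing here fixes its size or direction, and no step beyond the scatter is expected in this assay. The expected change a number 1 percentage points higher from compound 1 to compound 4 (within the scatter) is small. Compound 4 is estimated at 85% with an expected range of 70% to 96% around that middle.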

Compound 4, percent growth inhibition at one concentration: 76.6%
Compound 4: the middle estimate sits 8.4 percentage points above what was measured, and the stated range covers the measured number.
By their numbers in this assay, from the lowest: compound 3; then compounds 4, 1 and 2 (each within the scatter of the next, the first and the last beyond it).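

In this assay, going by these compounds alone, the change from 4-methylphenyl to 4-chlorophenyl gives a number 7.4 percentage points lower from compound 1 to compound 4 (within the scatter), so at this position chloro can stand in place of methyl with no step that can be told from the scatter. Within the data shown here, the earlier compounds held no pair differing in one place, so this is the first direct reading of any single change. No measured property of these compounds bears on this result.

On these data alone, whether an amine, a carboxylic acid or a longer chain at this position would keep growth inhibition at this level remains open.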